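This account rests on a few compounds, and the source may have more. Where it says the series, first, only, none or still open, it means among the compounds named here.

The measured compounds, each with its result in a functional assay on V79 cells (Cricetulus griseus) for cytotoxicity, read by colony formation; on this read-out lower numbers stand for stronger inhibition and higher numbers for weaker inhibition:
compound 1, `CC1(CN)CCN(c2c(F)cc3c(=O)c(C(=O)O)cn(C4CC4)c3c2Cl)C1`, gives 8 ug/mL;
compound 2, `COc1c(N2CCC(C)(CN)C2)c(F)cc2c(=O)c(C(=O)O)cn(C3CC3)c12`, gives 38 ug/mL;
compound 3, `NC1CCCN(c2c(F)cc3c(=O)c(C(=O)O)cn(C4CC4)c3c2Cl)C1`, gives 24 ug/mL.

Compound 1 carries the lowest number of the three. Compound 2 differs from it by methoxy in place of chloro on an aromatic carbon, and that change gave a 4.8-fold higher number from compound 1 to compound 2 (0.68 log units; beyond the scatter). Compound 3 differs from compound 1 by 3-aminopiperidin-1-yl in place of 3-(aminomethyl)-3-methylpyrrolidin-1-yl on an aromatic carbon, with a 3.0-fold higher number from compound 1 to compound 3 (0.48 log units; beyond the scatter). Compounds 2 and 3 lie within the usual scatter of each other, so nothing separates them.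

Compound 4, `COc1c(N2CCCC(N)C2)c(F)cc2c(=O)c(C(=O)O)cn(C3CC3)c12`, has not yet been measured. It differs from compound 3 by methoxy in place of chloro on an aromatic carbon. Among the compounds with values here, this is the same kind of change as the one from compound 1 to compound 2, but not the same: in compound 1 the place is ortho to a 3-(aminomethyl)-3-methylpyrrolidin-1-yl group (8 heavy atoms), whereas in compound 3 it is ortho to a 3-aminopiperidin-1-yl group (7 heavy atoms), the two cores differing by 3-aminopiperidin-1-yl in place of 3-(aminomethyl)-3-methylpyrrolidin-1-yl on an aromatic carbon as described.

Because compound 1 to compound 2 gave a 4.8-fold higher number from compound 1 to compound 2 (0.68 log units; beyond the scatter), a step of about the same size, a 4.2-fold higher number from compound 3 to compound 4 (0.62 log units; beyond the scatter), is expected from compound 3 to compound 4 in this assay. That expectation rests on a single earlier instance of the change, so its size is uncertain. Compound 4 is therefore estimated at 100 ug/mL in this assay, with a plausible range from 40 ug/mL to 300 ug/mL.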

Compound 4, half-maximal inhibitory concentration: 69 ug/mL
Compound 4: middle estimate off by 1.4-fold (0.16 log units), on the high side; the measured number falls inside the stated range.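

In this assay, methoxy in place of chloro gave a 2.9-fold higher number from compound 3 to compound 4 (0.46 log units; beyond the scatter), so the change carried over to the core bearing 3-aminopiperidin-1-yl with no difference beyond the scatter from its first instance: the same change on two cores in this assay, a 4.8-fold higher number (0.68 log units; beyond the scatter) from compound 1 to compound 2 and a 2.9-fold higher number (0.46 log units; beyond the scatter) from compound 3 to compound 4, 1.7-fold (0.22 log units) apart, within the scatter of two such steps. The exchange of 3-(aminomethyl)-3-methylpyrrolidin-1-yl for 3-aminopiperidin-1-yl gave a 1.8-fold higher number from compound 2 to compound 4 (0.26 log units; within the scatter) on the methoxy-bearing core, a step that on its own stands within the scatter, and it does not differ from the step seen on the chloro-bearing core: the same change on two cores in this assay, a 3.0-fold higher number (0.48 log units; beyond the scatter) from compound 1 to compound 3 and a 1.8-fold higher number (0.26 log units; within the scatter) from compound 2 to compound 4, 1.7-fold (0.22 log units) apart, within the scatter of two such steps. Across these four compounds, then, each change behaves much the same on both cores, but this rests on only two instances of each, and it does not show that the two steps are identical in size or that they would carry over to any other core.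

The compounds shown leave open whether the same steps would appear with other groups in place of chloro or methoxy, such as ethoxy or a plain hydrogen, or with other amines on the aromatic carbon, such as piperazine. They also leave open what would happen with an ethyl group in place of the cyclopropyl group.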